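The source may hold more compounds than are shown below. What is called first, only, known or untested is meant among the compounds shown, and "the series" means these compounds.

Within the data shown here, compound 2, `N=C(Nc1cccc(C(F)(F)F)c1)c1cc2c(-c3ccccc3)n[nH]c2cn1`, is the weakest of the three compounds measured so far in a functional assay on PC-3 cells (Homo sapiens) for cytotoxicity, read by MTT assay, with a stated time of 72 h; a lower number here means a stronger inhibitor, a higher number a weaker inhibitor: compound 2 gives 19900 nM, a number that sits beyond the usual scatter above both of its neighbours. Compound 1, `N=C(Nc1ccccc1)c1cc2c(-c3ccccc3)n[nH]c2c(NC2CCCCC2)n1`, carries a cyclohexylamino group on the shared core and in this assay compound 1 gives 1730 nM. Compound 3, `COc1ccc(Cn2nc(-c3ccccc3)c3cc(C(=N)Nc4ccc(N5CCN(C)CC5)cc4)nc(NC4CCCCC4)c32)cc1`, combines that cyclohexylamino group with a 4-methoxybenzyl group and a different substituted aniline, and in this assay compound 3 gives 3540 nM. Among the measured compounds shown here, no single-change step between measured compounds is available, so the gap between compound 2 and compound 3 reflects several changes at once.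

Compound 4, `COc1ccc(Cn2nc(-c3ccccc3)c3cc(C(=N)Nc4cccc(C(F)(F)F)c4)ncc32)cc1`, is the unmeasured compound that follows from compound 2 by one change: 4-methoxybenzyl in place of hydrogen on an aromatic nitrogen. The 4-methoxybenzyl group enters on the aromatic nitrogen of the five-membered ring of the shared core. Whether this group alone accounts for any of the gap between compound 2 and compound 3 cannot be read from the numbers, because compound 3 also differs at other places. The author expects a modest step from compound 2 to compound 4 of a 2.5-fold lower number from compound 2 to compound 4 (0.40 log units; beyond the scatter), toward a lower number, and estimates for compound 4 a value of 8000 nM, within a range from 2500 nM to 25000 nM.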

Compound 4, half-maximal inhibitory concentration: > 50000 nM
Compound 4 gave a limit, no number; the forecaster's own chance of this, stated with the estimate: 10%; middle value at least 6.2-fold (0.79 log units) from the limit.
By their numbers in this assay, from the lowest: compound 1; then compound 3; then compound 2. At a limit, above all of these: compound 4.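

Among these compounds, this is the first view of the aromatic nitrogen of the five-membered ring changed on its own, and the change goes against a gain in cytotoxicity: 4-methoxybenzyl in place of hydrogen gives an at least 2.5-fold higher number from compound 2 to compound 4 (0.40 log units; beyond the scatter). In this assay, on these data alone, compound 4 gives > 50000 nM, a limit and not a number, so the step sets only a floor for the loss and its full size stays unknown: the limit of > 50000 nM in this assay, at which 1 of the 4 values shown sits. Compound 3 also carries the 4-methoxybenzyl group, but it differs from compound 4 in more than one place, so the step applies only to the setting of this pair and not to compound 3.

The compounds shown leave open whether a methyl group or an unsubstituted benzyl on the same nitrogen would bring a similar loss, and so whether the outcome belongs to any group at this position or to the 4-methoxybenzyl group alone. They also leave open whether the same change would give a similar step on a core that carries the cyclohexylamino group of compound 1.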